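Moving from cyclopentyl to cyclobutylmethyl on the ring oxygen

A few compounds are considered here, and "the series" means these few. Any claim that something is new, unique, unknown or untested is made for them only; others in the source may bear on it.

Of the compounds shown here, two have been measured in an ADME assay on cells (Hepatocyte, Rattus norvegicus) for metabolic stability; a higher number here means faster removal of the compound, a lower number slower removal. Compound 1, with the structure `COc1cc2c(Nc3cnc(NC(=O)c4cccn4C)nc3)ncnc2cc1OCCCNC1CCCC1`, gives < 1 uL/min, and this is a limit of the assay rather than a number; it sits at the limit of < 1 uL/min in this assay, at which 1 of the 2 values shown sits. Compound 2, with the structure `CNc1nc(OC2CCCC2)nc2c1ncn2Cc1c(F)cccc1F`, gives 190 uL/min in this assay, the only plain number shown, so it stands as the one compound here with a measured rate of removal.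

Compound 3, with the structure `CNc1nc(OCC2CCC2)nc2c1ncn2Cc1c(F)cccc1F`, has not yet been measured. It differs from compound 2 in one place: cyclobutylmethyl in place of cyclopentyl on an oxygen on an aromatic ring. The two have the same atoms, joined differently.

Within the data shown here, no measured step between compounds that differ in one place is available, so the expectation rests on the structural change alone. The step from compound 2 to compound 3 in this assay is expected to be small, a 1.3-fold lower number from compound 2 to compound 3 (0.10 log units; within the scatter), and not beyond the usual scatter in either direction. Compound 3 is therefore estimated to give 150 uL/min in this assay, with a range from 60 uL/min to 400 uL/min.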

Compound 3, intrinsic clearance in a liver preparation (reported as CLH), per the amount of preparation that the assay uses in the Hepatocyte assay: 160 uL/min
For compound 3 the middle estimate is 1.1-fold (0.03 log units) below the measured one; the range from low to high includes it.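

Among these compounds, in the Hepatocyte assay the exchange of cyclopentyl for cyclobutylmethyl on an oxygen on an aromatic ring is the first step at this position that can be read, and it comes to a 1.2-fold lower number from compound 2 to compound 3 (0.07 log units; within the scatter), so this read-out does not tell the two compounds apart. In a physicochemical assay for solubility (a higher number here means a more soluble compound, a lower number a less soluble compound), compound 2 gives 9000 nM and compound 3 gives 4000 nM in the same test. The same change, which keeps the atoms and only joins them differently, therefore does separate the two compounds on this second measure, though only modestly: the measured solubility of compound 2, 9000 nM, and of compound 3, 4000 nM, a 2.3-fold lower number (0.35 log units; beyond the scatter).

Going by these compounds, both groups are made of carbon only and have the same count of heavy atoms, so it remains open whether a group carrying an amine, or a longer chain, on this oxygen would shift either number further. On these data alone, it is also open whether a carboxylic acid at this place would change the rate of removal, which has so far stayed within the scatter for this one exchange.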